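Acetamido in place of ((tert-butyl)carbonyl)oxy in the series

The source may hold more compounds than are shown below. What is called first, only, known or untested is meant among the compounds shown, and "the series" means these compounds.

In a functional assay on COLO 205 cells (Homo sapiens) for antiproliferative activity (a higher number here means a weaker inhibitor of growth, a lower number a stronger inhibitor of growth), compound 1 (`CCCCCOCCCCCCC/C=C1\CC(CO)(COC(=O)C(C)(C)C)OC1=O`) gives 0.491 ug/mL. Compound 2 (`CC(C)(C)C(=O)OCCCCCCCCCCCCCCC/C=C1\CC(CO)(COC(=O)C(C)(C)C)OC1=O`) gives 0.597 ug/mL, the higher of the two numbers but within the scatter of compound 1. Compound 3 (`CC(=O)NCCCCCCCCCCCCCCC/C=C1\CC(CO)(COC(=O)C(C)(C)C)OC1=O`) differs from compound 2 by acetamido in place of ((tert-butyl)carbonyl)oxy on a saturated chain carbon, ten or more bonds along the chain from a double-bonded chain carbon. Going by the values given here, no measured step covers this change, so the expectation starts from compound 2 at 0.597 ug/mL, with no step beyond the scatter expected in this assay, in either direction. The estimated step is a 1.0-fold higher number from compound 2 to compound 3 (0.00 log units; within the scatter). Compound 3 is expected at 0.6 ug/mL, within an estimated range of 0.25 ug/mL to 1.4 ug/mL.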

Compound 3, concentration for 50% growth inhibition: 4.74 ug/mL
Beside the measured number, compound 3's estimate is 7.9-fold (0.90 log units) below it, and the stated range ends below it.
By their numbers in this assay, from the lowest: compounds 1 and 2 (each within the scatter of the next); then compound 3.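

In this assay this position is not indifferent to the group it carries: acetamido in place of ((tert-butyl)carbonyl)oxy gives a 7.9-fold higher number from compound 2 to compound 3 (0.90 log units; beyond the scatter) and so a weaker inhibitor of growth, while 8-acetamidooctyl in place of pentyloxy gives a 9.7-fold higher number from compound 1 to compound 3 (0.98 log units; beyond the scatter) on the same reading. Compound 1 and compound 2 stood within the scatter of each other despite their different chain ends, so this sensitivity appears only with compound 3. Nothing available bears on the reason for these steps.

Open, on these data alone, is whether an amine, a carboxylic acid or a methyl ester at this place would read like acetamido or like ((tert-butyl)carbonyl)oxy.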